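The compounds below may be only part of what the source reports. "The series", "measured", "known", "first", "only" and "open" are said of these compounds alone.

Measured so far:
- compound 1 `O=C(Oc1ccc(S(=O)(=O)N2CCCC2)cc1)N1CCC(C(O)(c2ccccc2)c2ccccc2)CC1`: 49 nM
- compound 2 `CS(=O)(=O)c1ccc(OC(=O)N2CCC(C(O)(c3ccccc3)c3ccccc3)CC2)cc1`: 141 nM

In a functional assay for antagonist activity at Neuropeptide Y receptor type 2 (Homo sapiens) (on this read-out lower numbers stand for stronger inhibition and higher numbers for weaker inhibition), compound 2 gives the higher of the two numbers shown, standing a clear step above compound 1, which gives 49 nM in this assay. Compound 3 `CCS(=O)(=O)c1ccc(OC(=O)N2CCC(C(O)(c3ccccc3)c3ccccc3)CC2)cc1` has not yet been measured. It differs from compound 2 by methyl in place of hydrogen on a saturated chain carbon bound to a sulfonyl sulfur. Going by the values given here, no measured pair reproduces this change. Among the compounds with values here, the only step known, a 2.9-fold higher number from compound 1 to compound 2 (0.46 log units; beyond the scatter), concerns the same sulfonyl sulfur and shows that a smaller substituent there went with a weaker result, so compound 3, whose ethyl group stands between methyl and pyrrolidin-1-yl, is expected to give a number somewhat lower than compound 2, though the step may not exceed the scatter. On that basis compound 3 is estimated at 100 nM, with a range from 40 nM to 250 nM, amounting to an expected 1.4-fold lower number from compound 2 to compound 3 (0.15 log units; within the scatter).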

Compound 3, half-maximal inhibitory concentration: 59 nM
Beside the measured number, compound 3's estimate is 1.7-fold (0.23 log units) above it, and the stated range covers the measured number.
By their numbers in this assay, from the lowest: compounds 1 and 3 (each within the scatter of the next); then compound 2.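

Replacing methyl with ethyl gives a 2.4-fold lower number from compound 2 to compound 3 (0.38 log units; beyond the scatter) in this assay, so a single added methyl on a saturated chain carbon bound to a sulfonyl sulfur is enough to move the number beyond the scatter. The other new comparison gives a 1.2-fold higher number from compound 1 to compound 3 (0.08 log units; within the scatter) and places the ethyl group of compound 3 and the pyrrolidin-1-yl group of compound 1 within the scatter of each other, so among these compounds the ring is not needed to reach this level. No measurement offered here explains either result.

The compounds shown leave open whether a longer chain such as propyl, or a branched group such as isopropyl, would continue this trend or reverse it. They also do not show how a small open-chain amine such as dimethylamino on the sulfonyl sulfur would compare with ethyl or pyrrolidin-1-yl.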